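Amine variation on the side chain: compound 3 to compound 4

The compounds below may be only part of what the source reports. "The series", "measured", "known", "first", "only" and "open" are said of these compounds alone.

compound 1 `CN(C)CCn1c2ccc3ccccc3c2c2nc3ccccc3nc21`: in an assay on nucleic acid for binding affinity to Calf thymus DNA (Bos taurus) (on this read-out lower numbers stand for stronger inhibition and higher numbers for weaker inhibition), compound 1 gives 14500 nM
compound 2 `CCN(CC)CCn1c2ccc3ccccc3c2c2nc3ccccc3nc21`: compound 2 gives 20400 nM
compound 3 `CC1CCCCN1CCn1c2ccc3ccccc3c2c2nc3ccccc3nc21`: compound 3 gives 18600 nM

Compound 3 stands second highest of the three numbers, and its gaps to compound 1 and to compound 2 both lie within the scatter. The next member is compound 4 `CN1CCN(CCn2c3ccc4ccccc4c3c3nc4ccccc4nc32)CC1`, in which (4-methylpiperazin-1-yl in place of 2-methylpiperidin-1-yl on a saturated chain carbon, two bonds along the chain from an aromatic nitrogen). Among the compounds with values here, the steps that bear on this are the earlier exchanges at the same place: a 1.3-fold higher number from compound 1 to compound 3 (0.11 log units; within the scatter) and a 1.1-fold lower number from compound 2 to compound 3 (0.04 log units; within the scatter), alongside a 1.4-fold higher number from compound 1 to compound 2 (0.15 log units; within the scatter). None of the three amines tried so far has moved the number beyond the scatter. For compound 4 no step beyond the scatter is therefore expected in this assay, the expected change being a 1.1-fold lower number from compound 3 to compound 4 (0.04 log units; within the scatter). Compound 4 is estimated at 17000 nM, with a range from 8000 nM to 36000 nM.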

Compound 4, half-maximal inhibitory concentration: 14500 nM
The estimate for compound 4 lay 1.2-fold (0.07 log units) above the measured number; low and high end bracket the measured number.
By their numbers in this assay, from the lowest: compounds 1, 4, 3 and 2 (each within the scatter of the next).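

Exchanging the ring with 1 hetero atom for 4-methylpiperazin-1-yl, a ring with 2 hetero atoms, stays within the scatter in this assay: a 1.3-fold lower number from compound 3 to compound 4 (0.11 log units; within the scatter), a 1.4-fold lower number from compound 2 to compound 4 (0.15 log units; within the scatter) and no change at the digits printed from compound 1 to compound 4 (within the scatter). All four amines at this place, on a saturated chain carbon, two bonds along the chain from an aromatic nitrogen, thus lie within the scatter of one another, now including a ring with a second nitrogen. Nothing at hand accounts for this flat result. As far as these compounds go, whether a morpholin-4-yl group, a primary amine or a longer chain would move the number beyond the scatter remains open.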